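Replacing cyclohexyl with 1H-indol-4-yl in the series

The source may report more compounds than this note shows. Statements on the series, on what has been measured and on what is new or still open speak of the compounds shown alone.

Measured in a physicochemical assay for solubility; on this read-out higher numbers stand for higher solubility and lower numbers for lower solubility
- compound 1 `CNC(=O)c1cc(C(=O)NC2CC2)cn(Cc2ccc(C)cc2)c1=O` gives 24 ug/mL
- compound 2 `CNC(=O)c1cc(C(=O)NC2CC2)cn(Cc2cccc(F)c2)c1=O` gives >= 133 ug/mL as a limit
- compound 3 `CNC(=O)c1cc(C(=O)NC2CC2)cn(CC2CCCCC2)c1=O` gives >= 148 ug/mL as a limit

Compound 3 is known only by the limit >= 148 ug/mL and not by a number. Compound 4 `CNC(=O)c1cc(C(=O)NC2CC2)cn(Cc2cccc3[nH]ccc23)c1=O` differs from it by 1H-indol-4-yl in place of cyclohexyl on a saturated chain carbon bound to an aromatic nitrogen and remains unmeasured. For the measured compounds named here, two measured steps bear on this change, an at least 6.1-fold higher number from compound 1 to compound 3 (0.79 log units; beyond the scatter) and an at least 5.5-fold higher number from compound 1 to compound 2 (0.74 log units; beyond the scatter) with both beyond the scatter. Compound 1 and compound 2 both carry aromatic groups, yet only compound 1 gives a number, so aromatic groups do not behave alike here. A modest step to a lower number is expected, estimated as an at least 2.9-fold lower number from compound 3 to compound 4 (0.47 log units; beyond the scatter) in this assay for now. The estimate for compound 4 is 50 ug/mL with an expected range from 15 ug/mL to 150 ug/mL.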

Compound 4, solubility: 78 ug/mL
The estimate for compound 4 lay 1.6-fold (0.19 log units) below the measured number; the measured number falls inside the stated range.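

In this assay, 1H-indol-4-yl is a second aromatic group at this place that gives a number, and it separates from 4-methylphenyl with a 3.3-fold higher number from compound 1 to compound 4 (0.51 log units; beyond the scatter). Against cyclohexyl and 3-fluorophenyl only floors can be read, an at least 1.8-fold lower number from compound 3 to compound 4 (0.27 log units; that floor lies within the scatter) and an at least 1.7-fold lower number from compound 2 to compound 4 (0.23 log units; that floor lies within the scatter). Compound 3 is known only by a limit: the limit of >= 148 ug/mL in this assay, at which 1 of the 4 values shown sits.

As far as these compounds go, compound 2 is also known only by a limit, so the true size of both floored steps stays open: the limit of >= 133 ug/mL in this assay, at which 1 of the 4 values shown sits. Also open is how a pyridinyl group, an aminomethylphenyl group or a longer chain would read at this place in this assay.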